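Replacing 4-chlorophenyl with 3-(methanesulfonamido)phenyl: an efficacy estimate

The compounds below may be only part of what the source reports. "The series", "measured", "known", "first", "only" and "open" are said of these compounds alone.

Compound 1, `COc1cc(-c2nc(C(c3ccc(F)cc3)c3ccc(F)cc3)sc2CC(=O)O)ccn1`, in an in vitro functional assay on HEK285-7 cells for antagonist activity at prostaglandin D2 receptor 2 (Homo sapiens), read by BRET and beta-arrestin recruitment (a higher number here means a larger maximal response, a lower number a smaller maximal response), gives 60%.
Compound 2, `O=C(O)Cc1sc(C(c2ccc(F)cc2)c2ccc(F)cc2)nc1-c1ccc(Cl)cc1`, gives 80%.

Compound 2 stands highest of the two numbers; its nearest neighbour is compound 1, with a number 20 percentage points higher from compound 1 to compound 2 (beyond the scatter). Compound 3, `CS(=O)(=O)Nc1cccc(-c2nc(C(c3ccc(F)cc3)c3ccc(F)cc3)sc2CC(=O)O)c1`, differs from compound 2 by 3-(methanesulfonamido)phenyl in place of 4-chlorophenyl on an aromatic carbon. Within the data shown here, no measured step covers this change; the one step at the same position, a number 20 percentage points higher from compound 1 to compound 2 (beyond the scatter), was modest, so a step of similar size in either direction, or none beyond the scatter, is possible. Compound 3 is therefore expected to give 70%, between 50% and 90%, a step of a number 10 percentage points lower from compound 2 to compound 3 (within the scatter) being the estimate.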

Compound 3, largest response reached (reported as efficacy), in percent of the reference or control that the assay uses: 80%
Estimate against measurement, compound 3: 10 percentage points below, within the range that was stated.
By their numbers in this assay, from the lowest: compound 1; then compounds 2 and 3 (each within the scatter of the next).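

In this assay, 3-(methanesulfonamido)phenyl took the place of 4-chlorophenyl on this aromatic carbon with no change at the digits printed from compound 2 to compound 3 (within the scatter), so an entering group with more heavy atoms and a hydrogen-bond donor left the read-out where it stood. Measured against 2-methoxypyridin-4-yl, it gave a number 20 percentage points higher from compound 1 to compound 3 (beyond the scatter), matching the rise already seen with 4-chlorophenyl. Nothing available explains why these two different phenyl groups read alike. The compounds shown leave open how a phenyl bearing an amine or a carboxylic acid would read at this position. They also leave open how an unsubstituted phenyl would compare.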